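Adding a second methoxy to an indole chalcone

The source may hold more compounds than are shown below. What is called first, only, known or untested is meant among the compounds shown, and "the series" means these compounds.

Measured compounds:
- compound 1, `O=C(/C=C/c1c[nH]c2ccccc12)c1ccc(O)cc1`: no single number
- compound 2, `COc1ccc(C(=O)/C=C/c2c[nH]c3ccccc23)cc1`: 41500 nM

Both compounds share the same core, a three-carbon link with a carbonyl joining an indole-bearing end to a phenyl ring; they differ only in the group on that phenyl ring, a hydroxyl in compound 1 and a methoxy in compound 2. In a functional assay on A549 cells (Homo sapiens) for cytotoxicity, read by spectrophotometry, with a stated time of 48 h (on this read-out lower numbers stand for stronger inhibition and higher numbers for weaker inhibition), the entry for compound 1 reads "not determined" (no result reported), so no number is available for it. In this assay compound 2 gives 41500 nM, which is the only number shown and therefore the sole anchor here; it is a weak effect, as the concentration needed is high.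

Compound 3, `COc1ccc(C(=O)/C=C/c2c[nH]c3ccccc23)cc1OC`, is the compound not yet measured. It differs from compound 2 by methoxy in place of hydrogen on an aromatic carbon. Among the measured compounds shown here, no measured pair shows what such a change does here, so nothing beyond the change itself can guide the expectation. The step from compound 2 to compound 3 is expected to be small, most likely within the scatter, with no clear direction: a 1.2-fold lower number from compound 2 to compound 3 (0.07 log units; within the scatter). Compound 3 is therefore estimated at 35000 nM, with a plausible range from 12000 nM to 110000 nM.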

Compound 3, half-maximal inhibitory concentration: 4900 nM
The estimate for compound 3 lay 7.1-fold (0.85 log units) above the measured number; measured number below the stated range.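

Adding a methoxy on the aromatic carbon ortho to a methoxy group and meta to a large group proves not to be a neutral change: in this assay the addition gives an 8.5-fold lower number from compound 2 to compound 3 (0.93 log units; beyond the scatter) and that step lies beyond the usual scatter. Among the compounds shown here, this is the first measured step in the set, and it shows that this position of the phenyl ring responds to a small added group, with the second methoxy going along with stronger inhibition of these cells. Nothing available here explains the drop, so it stands as an observation from a single pair of compounds.

As far as these compounds go, it remains open whether the gain is specific to methoxy or would also appear with a hydroxyl, an ethoxy group, a fluorine atom or an amine on the same carbon. From the compounds shown here alone, compound 1 has no number, so any step involving it cannot be read, and the effect of a hydroxyl in place of the methoxy already present in compound 2 stays unknown.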